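A Trifluoromethoxy Swap at the Inhibition Limit

A few compounds are considered here, and "the series" means these few. Any claim that something is new, unique, unknown or untested is made for them only; others in the source may bear on it.

In an assay on isolated protein for inhibition of long-chain fatty acid transport protein 1 (Homo sapiens) (a lower number here means a stronger inhibitor, a higher number a weaker inhibitor), compound 2 `CCn1c(CNc2ccccc2)nnc1SCc1nc2cc(Cl)ccc2o1` gives > 1000 nM, which is a limit of the assay rather than a number. Compound 1 `CCC(O)c1ccc2oc(CSc3nnc(CNc4ccccc4)n3CC)nc2c1` in this assay gives > 1000 nM, likewise a limit. The two compounds are joined by a step that the two limits leave unreadable from compound 1 to compound 2, so that step carries no readable size; what the numbers show is summed up by the limit of > 1000 nM in this assay, at which 2 of the 2 values shown sit. Compound 3 `CCn1c(CNc2ccccc2)nnc1SCc1nc2cc(OC(F)(F)F)ccc2o1` differs from compound 2 by trifluoromethoxy in place of chloro on an aromatic carbon. Within the data shown here, no measured step bears on this change, and compound 2 stands only at a limit, so neither a direction nor a size beyond the scatter can be read from the data. Compound 3 is therefore expected to remain close to that limit, with an estimated step that the limit leaves unreadable from compound 2 to compound 3 in this assay. The estimate for compound 3 in this assay is 2000 nM, with a range from 500 nM to 10000 nM.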

Compound 3, half-maximal inhibitory concentration: 100 nM
Compound 3: middle estimate off by 20-fold (1.30 log units), on the high side; the measured number lies below the stated range.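

In this assay, the substituent on this aromatic carbon, which lies meta to a fused ring and para to a fused ring, proves able to move the compound off the limit. Trifluoromethoxy in place of chloro gives an at least 10-fold lower number from compound 2 to compound 3 (1.00 log units; beyond the scatter), and trifluoromethoxy in place of 1-hydroxypropyl gives an at least 10-fold lower number from compound 1 to compound 3 (1.00 log units; beyond the scatter). Each size is only a minimum, and the step from compound 1 to compound 2 cannot be read, so chloro and 1-hydroxypropyl cannot be ranked against each other: the limit of > 1000 nM in this assay, at which 2 of the 3 values shown sit.

The compounds shown leave open whether this gain is particular to trifluoromethoxy or would also appear with trifluoromethyl, methoxy or a nitrile at the same place. They also leave open whether a change elsewhere on the shared core would add to this step.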